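Swapping a Phenoxy for a Bromo on an Indole Thiourea

The compounds below may be only part of what the source reports. "The series", "measured", "known", "first", "only" and "open" are said of these compounds alone.

The series rests on a shared core, first seen in compound 1 `S=C(Nc1ccccc1)Nc1ccc2[nH]ccc2c1`. In an ADME assay on cells for inhibition of Amine oxidase [flavin-containing] A (Homo sapiens), read by spectrophotometry (a higher number here means a weaker inhibitor, a lower number a stronger inhibitor), compound 1 reaches only a limit of the assay, > 30000 nM. Compound 2 `S=C(Nc1ccc(Oc2ccccc2)cc1)Nc1ccc2[nH]ccc2c1` carries a phenoxy group on the second aryl ring. In this assay compound 2 is reported as "not active" (no number reported), with no number attached. Compound 2 therefore stands without a place on a numerical scale; the only number shown in the set is the limit of > 30000 nM in this assay, at which 1 of the 2 values shown sits, and that belongs to compound 1. The step to compound 3 `S=C(Nc1ccc(Br)cc1)Nc1ccc2[nH]ccc2c1` is bromo in place of phenoxy on an aromatic carbon. With neither measured compound yielding a number, no step is expected to be resolved beyond the scatter in this assay, and in either direction. Compound 3 is expected to give about 30000 nM in this assay, within an estimated range of 5000 nM to 100000 nM.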

Compound 3, half-maximal inhibitory concentration: 5900 nM
The estimate for compound 3 lay 5.1-fold (0.71 log units) above the measured number; measured number inside the range.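

Compound 3 gives the series its first number in this assay that is not a limit, and it shows that this place, on an aromatic carbon para to a large group, can register a change: bromo in place of hydrogen gives an at least 5.0-fold lower number from compound 1 to compound 3 (0.70 log units; beyond the scatter). Compound 1 stands at a limit of the assay and not at a number, so this step has a bound but no exact size: the limit of > 30000 nM in this assay, at which 1 of the 3 values shown sits. The change from phenoxy to bromo cannot be read as a step, as compound 2 carries no number.

The compounds shown leave open whether bromo is special at this place or whether chloro, methoxy or an amine would serve as well. They also leave open how bromo would read at any other carbon of the same ring.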